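The source may hold more compounds than are shown below. What is called first, only, known or untested is meant among the compounds shown, and "the series" means these compounds.

Measured compounds:
- compound 1, `CC(C)NC(=O)CC(c1ccc(-c2ccc3cccc(F)c3c2)[nH]c1=O)C(C)C`, 18000 nM
- compound 2, `CC(C)C(Nc1nccs1)c1ccc(-c2ccc3cccc(F)c3c2)[nH]c1=O`, 16100 nM
- compound 3, `CC(C)C(/C=C1\CCNC1=O)c1ccc(-c2ccc3cccc(F)c3c2)[nH]c1=O`, 20700 nM

All three numbers come from a physicochemical assay for solubility, in phosphate buffer, measured as kinetic solubility; on this read-out higher numbers stand for higher solubility and lower numbers for lower solubility. Compound 3 carries the largest of the three, but the steps that reach it are small: a 1.2-fold higher number from compound 1 to compound 3 (0.06 log units; within the scatter) and a 1.3-fold higher number from compound 2 to compound 3 (0.11 log units; within the scatter). The step of a 1.1-fold lower number from compound 1 to compound 2 (0.05 log units; within the scatter) is likewise within the scatter, so across the three the group on the saturated chain carbon bound to an aromatic carbon and a saturated chain carbon has not moved this assay.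

Compound 4, `Cc1c[nH]c(C(c2ccc(-c3ccc4cccc(F)c4c3)[nH]c2=O)C(C)C)n1`, differs from compound 3 as follows: a group of 6 heavy atoms (4 carbon, 2 nitrogen; one five-membered aromatic ring with 2 hetero atoms) in place of a group of 7 heavy atoms (5 carbon, 1 nitrogen, 1 oxygen; one five-membered non-aromatic ring with 1 hetero atom), on a saturated chain carbon bound to an aromatic carbon and a saturated chain carbon

For the measured compounds named here, the step that bears most on this is the one from compound 2 to compound 3, which exchanged an aromatic five-membered ring with two hetero atoms for the non-aromatic ring and stayed within the scatter; the step from compound 1 to compound 3 did the same. The change to compound 4 runs the other way, back to an aromatic five-membered ring with two hetero atoms. No step beyond the scatter is therefore expected in this assay. Compound 4 is estimated at 17000 nM, with a range of 9000 nM to 34000 nM. This estimate corresponds to an expected step of a 1.2-fold lower number from compound 3 to compound 4 (0.09 log units; within the scatter).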

Compound 4, solubility: 15200 nM
Compound 4: middle estimate off by 1.1-fold (0.05 log units), on the high side; the measured number falls inside the stated range.
By their numbers in this assay, from the lowest: compounds 4, 2, 1 and 3 (each within the scatter of the next).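

In this assay, 4-methyl-1H-imidazol-2-yl on the saturated chain carbon bound to an aromatic carbon and a saturated chain carbon stays within the scatter of all three earlier groups (a 1.4-fold lower number from compound 3 to compound 4 (0.13 log units; within the scatter); a 1.1-fold lower number from compound 2 to compound 4 (0.02 log units; within the scatter); a 1.2-fold lower number from compound 1 to compound 4 (0.07 log units; within the scatter)). For the compounds shown here, the four compounds now include a five-membered aromatic ring bound directly at this place, alongside (1,3-thiazol-2-yl)amino, the (isopropylcarbamoyl)methyl chain and the non-aromatic ring, and no pair among them differs beyond the scatter. No measured evidence accounts for this flat response.

Going by these compounds, whether a carboxylic acid or a primary amine at this place would give a step beyond the scatter in this assay remains open. Also open, on these data alone, is whether the flat response would hold with a change elsewhere on the shared core.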